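Swapping butyl for isobutyl on the sulfur

The source may hold more compounds than are shown below. What is called first, only, known or untested is meant among the compounds shown, and "the series" means these compounds.

Within the data shown here, in a functional assay on MT4 cells (Homo sapiens) for cytotoxicity (on this read-out higher numbers stand for lower toxicity in this test and lower numbers for higher toxicity in this test), compound 3 `CCCCSc1nc(O)c(C)c(C(C)c2c(F)cccc2F)n1` gives 112000 nM as the only true number so far. Compound 1 `CC(C)CSc1nc(O)cc(C(C)c2c(F)cccc2F)n1` shows > 200000 nM as a limit only. Compound 2 `CCC(C)Sc1nc(O)c(C)c(C(C)c2c(F)cccc2F)n1` likewise shows > 200000 nM as a limit only. Compound 4 `Cc1c(O)nc(SCC(C)C)nc1C(C)c1c(F)cccc1F` carries isobutyl where compound 3 carries butyl, which is isopropyl in place of propyl on a saturated chain carbon bound to a sulfur. Among the measured compounds shown here, the one measured step that bears on this is butyl in place of sec-butyl on a sulfur (an at least 1.7-fold lower number from compound 2 to compound 3 (0.25 log units; that floor lies within the scatter)), and its floor lies within the scatter. No step beyond the scatter is therefore expected in this assay for this change. The estimated step is a 1.3-fold higher number from compound 3 to compound 4 (0.13 log units; within the scatter) and stays within the scatter. Compound 4 is expected near 150000 nM with an estimated range of 80000 nM to 250000 nM in this read-out.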

Compound 4, half-maximal cytotoxic concentration: > 200000 nM
Compound 4 gave a limit, no number; the forecaster's own chance of this, stated with the estimate: 45%; middle value at least 1.3-fold (0.12 log units) from the limit.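

In this assay, from the compounds shown here alone, isobutyl in place of butyl on the sulfur gives an at least 1.7-fold higher number from compound 3 to compound 4 (0.25 log units; that floor lies within the scatter), so the change shows no step beyond the scatter, and its true size stays unknown. With sec-butyl and now isobutyl both ending at a limit, only the straight butyl of compound 3 gives a true number, and the steps from compound 1 and compound 2 to compound 4 cannot be read. Most of this small set gives no number: the limit of > 200000 nM in this assay, at which 3 of the 4 values shown sit.

Open, going by these compounds, is how a hexyl chain or an amine in place of the butyl would read here.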